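The compounds below may be only part of what the source reports. "The series", "measured", "known", "first", "only" and "open" are said of these compounds alone.

Measured in a functional assay on DU-145 cells (Homo sapiens) for inhibition; on this read-out lower numbers stand for stronger inhibition and higher numbers for weaker inhibition:

compound 1 (`N[C@H]1CC[C@H](Nc2nc(NCc3cccc(I)c3)c3ncn(C4CCCC4)c3n2)CC1`) : 1600 nM
compound 2 (`N[C@H]1CC[C@H](Nc2nc(NCC3CC3)c3ncn(C4CCCC4)c3n2)CC1`) : 1300 nM

These two values lie within the scatter of each other, so compound 2 cannot be ranked against compound 1. Compound 3 (`C[C@H](Nc1nc(N[C@H]2CC[C@H](N)CC2)nc2c1ncn2C1CCCC1)c1ccccc1`) has not yet been measured. It differs from compound 2 at one place: 1-phenylethyl in place of cyclopropylmethyl on a nitrogen on an aromatic ring. In words, 1-phenylethyl stands in place of cyclopropylmethyl on a nitrogen on an aromatic ring. Among the compounds with values here, the only measured step bearing on this substituent is a 1.2-fold lower number from compound 1 to compound 2 (0.09 log units; within the scatter), with cyclopropyl in place of 3-iodophenyl. Within the data shown here, that exchange stayed within the scatter, though one step is thin evidence and no measured compound carries 1-phenylethyl. In this assay no change beyond the scatter is therefore expected, and the estimated step is a 1.1-fold higher number from compound 2 to compound 3 (0.03 log units; within the scatter). For compound 3 the expected value is 1400 nM, with an estimated range from 500 nM to 3800 nM.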

Compound 3, half-maximal inhibitory concentration: 5600 nM
Beside the measured number, compound 3's estimate is 4.0-fold (0.60 log units) below it, and the stated range ends below it.
By their numbers in this assay, from the lowest: compounds 2 and 1 (each within the scatter of the next); then compound 3.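

In this assay, the group on this nitrogen now makes a measurable difference: 1-phenylethyl in place of cyclopropylmethyl gives (a 4.3-fold higher number from compound 2 to compound 3 (0.63 log units; beyond the scatter)), and 1-phenylethyl in place of 3-iodobenzyl gives (a 3.5-fold higher number from compound 1 to compound 3 (0.54 log units; beyond the scatter)). An aromatic ring in this group does not alone set the number, as compound 1 carries one and remains within the scatter of compound 2, whereas compound 3 stands apart from both. Nothing available explains this separation.

Compound 3 differs from compound 1 in both the iodine and the extra methyl, so the compounds shown cannot assign the step to either, and unsubstituted benzyl would separate the two. Also open, on these data alone, are the other configuration of the defined stereocentre and a longer chain such as 2-phenylethyl.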